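Amide substituent change from methoxyphenyl to methylisoxazolyl

A few compounds are considered here, and "the series" means these few. Any claim that something is new, unique, unknown or untested is made for them only; others in the source may bear on it.

Compound 1 `COc1cccc(NC(=O)COc2ccc3cc(/C=C4/SC(=O)NC4=O)ccc3c2)c1`: 7600 nM
Compound 2 `COc1ccc(NC(=O)COc2ccc3cc(/C=C4/SC(=O)NC4=O)ccc3c2)cc1`: > 50000 nM

In an assay on isolated protein for inhibition of histone deacetylase 8 (Homo sapiens), with a stated time of 1 h (on this read-out lower numbers stand for stronger inhibition and higher numbers for weaker inhibition), compound 1 gives 7600 nM. Compound 2 sits at a limit of this assay, > 50000 nM, so only a bound is known for it (the limit of > 50000 nM in this assay, at which 1 of the 2 values shown sits). Among the compounds with values here, the one measured step, an at least 6.5-fold higher number from compound 1 to compound 2 (0.81 log units; beyond the scatter), shows the amide substituent matters. Compound 3 `Cc1cc(NC(=O)COc2ccc3cc(/C=C4/SC(=O)NC4=O)ccc3c2)no1` differs from compound 2 by 5-methyl-1,2-oxazol-3-yl in place of 4-methoxyphenyl on an amide-type nitrogen. Within the data shown here, no measured step covers this change, so the expected step of an at least 2.5-fold lower number from compound 2 to compound 3 (0.39 log units; beyond the scatter) is uncertain. The estimated value for compound 3 is 20000 nM, within 4000 nM to 100000 nM.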

Compound 3, half-maximal inhibitory concentration: > 50000 nM
Compound 3: a limit, no number (the forecaster's own chance of this, stated with the estimate: 45%); middle value at least 2.5-fold (0.39 log units) from the limit.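

In this assay compound 3 also sits at a limit, > 50000 nM, which is not a number. Changing the substituent on the amide-type nitrogen gives an at least 6.5-fold higher number from compound 1 to compound 3 (0.81 log units; beyond the scatter), so a second substituent, this time with a five-membered ring, falls short of the 3-methoxyphenyl group. The step between compound 2 and compound 3 cannot be read, since both values are limits: the limit of > 50000 nM in this assay, at which 2 of the 3 values shown sit.

As far as these compounds go, how far either compound lies past that limit remains open. So does whether a pyridinyl or aminophenyl group on this nitrogen would give a lower number than compound 1.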